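A Dihydroxy Side Chain Joins Three Near-Identical Weak Inhibitors

The source may report more compounds than this note shows. Statements on the series, on what has been measured and on what is new or still open speak of the compounds shown alone.

Compound 1, `C=CC(C)(C)c1[nH]c2ccc(C[C@@H](Cl)C(C)(C)O)cc2c1/C=C1\NC(=O)[C@H](C)NC1=O`, in a functional assay; a lower number here means a stronger inhibitor, a higher number a weaker inhibitor: 97000 nM
Compound 2, `C=CC(C)(C)c1[nH]c2ccc(C[C@@H](O)C(=C)C)cc2c1/C=C1\NC(=O)[C@H](C)NC1=O`, in this assay: 75000 nM
Compound 3, `C=CC(C)(C)c1[nH]c2ccc(CC(=O)C(C)C)cc2c1/C=C1\NC(=O)[C@H](C)NC1=O`, in this assay: 79000 nM

The three measured compounds share one core and differ only in the side chain on a saturated chain carbon bound to an aromatic carbon. Compound 3 stands second highest of the three numbers; its nearest neighbour is compound 2 and its furthest is compound 1, and neither gap reaches beyond the scatter. Every measured step tells the same story: a 1.3-fold lower number from compound 1 to compound 2 (0.11 log units; within the scatter), a 1.2-fold lower number from compound 1 to compound 3 (0.09 log units; within the scatter) and a 1.1-fold higher number from compound 2 to compound 3 (0.02 log units; within the scatter). Whatever the side chain has been so far, the assay has not moved.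

Compound 4, `C=CC(C)(C)c1[nH]c2ccc(C[C@@H](O)C(C)(C)O)cc2c1/C=C1\NC(=O)[C@H](C)NC1=O`, has not yet been measured. Relative to compound 3 the change is 1,2-dihydroxy-2-methylpropyl in place of isopropylcarbonyl on a saturated chain carbon bound to an aromatic carbon. The 1,2-dihydroxy-2-methylpropyl group resembles the hydroxylated chains of compound 1 and compound 2 more than the isopropylcarbonyl of compound 3, yet those three chains gave indistinguishable numbers.

Compound 4 is therefore expected to give 80000 nM in this assay, with a range from 40000 nM to 160000 nM. The expected step is a 1.0-fold higher number from compound 3 to compound 4 (0.01 log units; within the scatter), which amounts to no change beyond the scatter.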

Compound 4, half-maximal inhibitory concentration: 79000 nM
The estimate for compound 4 lay 1.0-fold (0.01 log units) above the measured number; the measured number falls inside the stated range.
By their numbers in this assay, from the lowest: compounds 2, 3, 4 and 1 (each within the scatter of the next).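

The result adds the first chain with 2 hydrogen-bond donors to sit against the 0 of isopropylcarbonyl: no change at the digits printed from compound 3 to compound 4 (within the scatter) is what this assay shows when 1,2-dihydroxy-2-methylpropyl takes the place of isopropylcarbonyl on a saturated chain carbon bound to an aromatic carbon, and the defined stereocentre that enters with it leaves the reading equally flat. Two narrower exchanges further out on the chain also become readable, with a 1.1-fold higher number from compound 2 to compound 4 (0.02 log units; within the scatter) for 1-hydroxy-1-methylethyl in place of 1-methylethenyl and a 1.2-fold lower number from compound 1 to compound 4 (0.09 log units; within the scatter) for hydroxy in place of chloro, so all four compounds now stand within the scatter of one another whether the chain carries a hydroxy, a chloro, an alkene or a ketone. Nothing at hand bears on why these chains do not separate.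

What the compounds shown leave open is whether any group at this place can move the number at all, since an amine, a carboxylic acid, a ring or a longer chain does not appear among them. Also open, on these data alone, is whether the opposite configuration at the carbon bearing the hydroxy would read the same.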